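A few compounds are considered here, and "the series" means these few. Any claim that something is new, unique, unknown or untested is made for them only; others in the source may bear on it.

In an assay for inhibition of Indoleamine 2,3-dioxygenase 1 (Homo sapiens), read by fluorescence, with a stated time of 1 h (on this read-out lower numbers stand for stronger inhibition and higher numbers for weaker inhibition), the three measured compounds stand as follows:

compound 1, `NS(=O)(=O)CC(=O)NCCSc1nonc1/C(=N/O)Nc1cccc(C(F)F)c1`: 130 nM
compound 2, `NS(=O)(=O)CC(=O)NCCSc1nonc1/C(=N/O)Nc1ccc(F)c(C(F)F)c1`: 73 nM
compound 3, `O=C(NCCSc1nonc1/C(=N/O)Nc1ccc(F)c(C(F)F)c1)C1CS(=O)(=O)C1`: 70 nM

Compound 2 sits between the other two on the numbers, but neither gap separates it from them: a 1.8-fold lower number from compound 1 to compound 2 (0.25 log units; within the scatter) and a 1.0-fold lower number from compound 2 to compound 3 (0.02 log units; within the scatter) both fall within the scatter, so the three compounds are indistinguishable on this read-out.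

Compound 4, `N#Cc1cccc(N/C(=N\O)c2nonc2SCCNC(=O)CS(N)(=O)=O)c1`, is not yet measured. It differs from compound 2 by 3-cyanophenyl in place of 3-(difluoromethyl)-4-fluorophenyl on an amine nitrogen. For the measured compounds named here, of the two measured steps only the one from compound 1 to compound 2 touches the same aromatic ring, and it is within the scatter; the step from compound 2 to compound 3 concerns the other end of the molecule and does not bear on this change. Going by the values given here, no measured pair swaps the whole aryl group, so there is no direct precedent. The expectation for compound 4 is therefore a small shift, a 2.1-fold higher number from compound 2 to compound 4 (0.31 log units; beyond the scatter), with a wide range. Compound 4 is estimated at 150 nM, between 50 nM and 450 nM.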

Compound 4, half-maximal inhibitory concentration: 240 nM
Compound 4: the middle estimate sits 1.6-fold (0.20 log units) below what was measured; measured number inside the range.
By their numbers in this assay, from the lowest: compounds 3, 2, 1 and 4 (each within the scatter of the next, the first and the last beyond it).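

In this assay, for the compounds shown here, replacing the whole aryl group on the amine nitrogen gives the first step that lies beyond the scatter (a 3.3-fold higher number from compound 2 to compound 4 (0.52 log units; beyond the scatter)), so this position does respond to the choice of aryl group. Cyano in place of difluoromethyl alone stays within the scatter (a 1.8-fold higher number from compound 1 to compound 4 (0.27 log units; within the scatter)), as does the listed fluoro change, so neither single change separates two compounds, and only the combined replacement does. No measured evidence explains the difference between these aryl groups.

As far as these compounds go, it remains open whether adding fluoro to the 3-cyanophenyl group of compound 4 would bring its number back to that of compound 2. Also open, from the compounds shown here alone, is how a trifluoromethyl group, a chlorine atom or a carboxylic acid would read in place of the cyano group.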